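The source may hold more compounds than are shown below. What is called first, only, known or untested is meant among the compounds shown, and "the series" means these compounds.

In an assay on cells for activation of Cystic fibrosis transmembrane conductance regulator (Homo sapiens), read by fluorescence, with a stated time of 10 min (on this read-out higher numbers stand for an effect only at larger amounts of compound and lower numbers for an effect already at smaller amounts), compound 1 `O=c1c(-c2cccc(Br)c2)nc2ccccc2n1Cc1ccccc1` gives 330 nM, compound 2 `O=c1c(-c2ccccc2)nc2ccccc2n1Cc1ccccc1` gives 5000 nM, and compound 3 `N#Cc1cccc(-c2nc3ccccc3n(Cc3ccccc3)c2=O)c1` gives 1000 nM.

Compound 3 stands second highest of the three numbers; the step of a 3.0-fold higher number from compound 1 to compound 3 (0.48 log units; beyond the scatter) is the smaller gap, the step of a 5.0-fold lower number from compound 2 to compound 3 (0.70 log units; beyond the scatter) the larger one. Compound 4 `O=c1c(-c2ccc3nonc3c2)nc2ccccc2n1Cc1ccccc1` differs from compound 3 by a group of 9 heavy atoms (6 carbon, 2 nitrogen, 1 oxygen; one five-membered aromatic ring with 3 hetero atoms, one six-membered aromatic ring of carbon only) in place of a group of 8 heavy atoms (7 carbon, 1 nitrogen; one six-membered aromatic ring of carbon only), on an aromatic carbon. All three measured steps, including a 15-fold higher number from compound 1 to compound 2 (1.18 log units; beyond the scatter), vary only the substituent on the ring that now leaves; none replaces that ring by a fused system, so the bearing is indirect. Since a substituted ring is retained and the bare ring of compound 2 gave the highest number, a modest step at most is expected. The step of a 1.4-fold lower number from compound 3 to compound 4 (0.15 log units; within the scatter) is expected to stay small. Compound 4 is estimated at 700 nM, with a range from 150 nM to 3500 nM.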

Compound 4, half-maximal effective concentration: 18 nM
Estimate against measurement, compound 4: 39-fold (1.59 log units) above; the whole stated range lies above it.
By their numbers in this assay, from the lowest: compound 4; then compound 1; then compound 3; then compound 2.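

Working notes: in this assay, a fused group on this aromatic carbon next to the ring nitrogen gives a lower number than every single-ring group shown: a 56-fold lower number from compound 3 to compound 4 (1.74 log units; beyond the scatter), an 18-fold lower number from compound 1 to compound 4 (1.26 log units; beyond the scatter), and a 280-fold lower number from compound 2 to compound 4 (2.44 log units; beyond the scatter). Replacing the whole ring here therefore reaches further than the widest substituent swap on the retained ring, a 15-fold higher number from compound 1 to compound 2 (1.18 log units; beyond the scatter). Nothing available explains the drop.

Open: whether the fusion itself or the hetero atoms of the five-membered ring carry the step. A naphthyl group at this position would separate the two.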